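From Compound 3 to Compound 4 at the Assay Limit

The source may hold more compounds than are shown below. What is called first, only, known or untested is meant among the compounds shown, and "the series" means these compounds.

Three related compounds have been tested for their ability to stop breast cancer cells from growing, and none gives a readable number. In a functional assay on MDA-MB-231 cells (Homo sapiens) for antiproliferative activity, read by CCK-8 assay, with a stated time of 48 h (a lower number here means a stronger inhibitor, a higher number a weaker inhibitor), compound 1 `CNC(=O)/C=C/CN1CC(Oc2ccc(Oc3c(-c4ccc(F)cc4)sc4cc(O)ccc34)cc2)C1` gives > 50000 nM, which is a limit of the assay and not a number. Compound 2 `C=CC(=O)NCCOc1ccc(Oc2c(-c3ccc(F)cc3)sc3cc(O)ccc23)cc1` gives > 50000 nM, again a limit. Compound 3 `CN(C)C(=O)/C=C/CNCCOc1ccc(Oc2c(-c3ccc(F)cc3)sc3cc(O)ccc23)cc1` gives > 50000 nM, a limit as well, so it stands level with the other two only in being unreadable.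

Compound 4 `C/C=C/C(=O)NCCOc1ccc(Oc2c(-c3ccc(F)cc3)sc3cc(O)ccc23)cc1` changes compound 3 on an amine nitrogen: (prop-1-en-1-yl)carbonyl in place of 3-(dimethylcarbamoyl)prop-2-en-1-yl on an amine nitrogen. In words, (prop-1-en-1-yl)carbonyl takes the place of 3-(dimethylcarbamoyl)prop-2-en-1-yl.

The measured step closest to this change is a step that the two limits leave unreadable from compound 2 to compound 3, made on the same amine nitrogen. The other two are a step that the two limits leave unreadable from compound 1 to compound 2 and a step that the two limits leave unreadable from compound 1 to compound 3. Because of the limit of > 50000 nM in this assay, at which 3 of the 3 values shown sit, none of these steps has a size or a direction, so they offer no sign of a gain or a loss. The expected step is a number no higher from compound 3 to compound 4 (the limit leaves the size open), with no direction expected beyond the scatter. Compound 4 is estimated at 50000 nM, with an expected range of 20000 nM to 100000 nM, and another limit is the likeliest report.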

Compound 4, half-maximal inhibitory concentration: > 50000 nM
Compound 4 gave a limit, no number; the forecaster's own chance of this, stated with the estimate: 80%; the middle value sits exactly at the limit.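

In this assay compound 4 gives > 50000 nM, which is a limit and not a number. The steps linking compound 4 to compound 1, compound 2 and compound 3 therefore cannot be read, because of this: the limit of > 50000 nM in this assay, at which 4 of the 4 values shown sit. The compounds shown leave open which groups on the shared core, if any, would give a readable number in this assay.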